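This account rests on a few compounds, and the source may have more. Where it says the series, first, only, none or still open, it means among the compounds named here.

Values so far in a functional assay on GC-2 cells (Mus musculus) for cytotoxicity, read by MTT assay, with a stated time of 72 h; a lower number here means a stronger inhibitor, a higher number a weaker inhibitor:

compound 1 `Nc1nc(Nc2ccc(S(N)(=O)=O)cc2)sc1C(=O)c1cccnc1` gives > 30000 nM as a limit
compound 2 `Nc1nc(Nc2ccc(S(N)(=O)=O)cc2)sc1C(=O)c1ccccc1[N+](=O)[O-]` gives 9000 nM as a number
compound 3 `Nc1nc(Nc2ccc(S(N)(=O)=O)cc2)sc1C(=O)c1cccc([N+](=O)[O-])c1` gives 20000 nM as a number

The reading for compound 1 is a limit of the assay and not a number. That leaves two true numbers, and compound 3 holds the higher one, which makes it the weaker inhibitor of that pair. The gap is a 2.2-fold higher number from compound 2 to compound 3 (0.35 log units; beyond the scatter) in size.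

Compound 4 `COc1cccc(C(=O)c2sc(Nc3ccc(S(N)(=O)=O)cc3)nc2N)c1` keeps the shared core and alters one group: methoxy in place of nitro on an aromatic carbon. In words, this is methoxy in place of nitro on an aromatic carbon, meta to a large group.

For the measured compounds named here, no measured step makes this exact exchange. The nearest evidence comes from steps that alter the same aromatic group on the carbonyl: a 2.2-fold higher number from compound 2 to compound 3 (0.35 log units; beyond the scatter), then an at least 3.3-fold lower number from compound 1 to compound 2 (0.52 log units; beyond the scatter) and an at least 1.5-fold lower number from compound 1 to compound 3 (0.17 log units; that floor lies within the scatter), where the last two are only floors. Going by the values given here, since the one firm step is the modest 2.2-fold higher number from compound 2 to compound 3 (0.35 log units; beyond the scatter), a small shift is expected, in no clear direction. The estimated change is a 1.1-fold lower number from compound 3 to compound 4 (0.05 log units; within the scatter) and is not expected to go beyond the scatter.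

For compound 4 the expected value is 18000 nM with an estimated range from 7000 nM to 30000 nM as its upper end.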

Compound 4, half-maximal inhibitory concentration: 11000 nM
Beside the measured number, compound 4's estimate is 1.6-fold (0.21 log units) above it, within the range that was stated.
By their numbers in this assay, from the lowest: compounds 2, 4 and 3 (each within the scatter of the next, the first and the last beyond it). At a limit, above all of these: compound 1.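

In this assay, methoxy in place of nitro on this aromatic carbon, meta to a large group, gives a 1.8-fold lower number from compound 3 to compound 4 (0.26 log units; within the scatter), so the data do not tell these two groups apart at this position. 3-Methoxyphenyl in place of 2-nitrophenyl gives a 1.2-fold higher number from compound 2 to compound 4 (0.09 log units; within the scatter), so compound 4 cannot be separated from compound 2 either, even though the step between compound 2 and compound 3 is beyond the scatter. 3-Methoxyphenyl in place of pyridin-3-yl gives an at least 2.7-fold lower number from compound 1 to compound 4 (0.43 log units; beyond the scatter), which is a floor and not a measured size, and the reading for compound 1 is a limit of the assay: the limit of > 30000 nM in this assay, at which 1 of the 4 values shown sits.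

The compounds shown leave open whether an amine or a carboxylic acid on the same aromatic carbon would give a number that stands apart from those of compound 3 and compound 4. From the compounds shown here alone, it also remains open whether a longer chain such as ethoxy in place of methoxy would move the number beyond the scatter from compound 4.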